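Adding a bromo group to compound 2

The source may hold more compounds than are shown below. What is called first, only, known or untested is meant among the compounds shown, and "the series" means these compounds.

compound 1 `C=CCOc1ccc(F)cc1C(=O)c1cccnc1` gives > 100000 nM
compound 2 `O=C(c1cccnc1)c1ccccc1O` gives 31000 nM
compound 3 `O=C(c1cccnc1)c1cccc(Cl)c1O` gives 28000 nM

In a functional assay on Hep cells (Homo sapiens) for cytotoxicity, read by sulforhodamine B assay, with a stated time of 48 h (on this read-out lower numbers stand for stronger inhibition and higher numbers for weaker inhibition), compound 1 gives only a limit, > 100000 nM, not a true number. The other two compounds give real numbers, and compound 2 stands within the scatter of compound 3 at 28000 nM. Compound 4 `O=C(c1cccnc1)c1cc(Br)ccc1O` differs from compound 2 by one swap (bromo in place of hydrogen on an aromatic carbon), with the bromo para to a hydroxy group. Within the data shown here, the only comparable measured swap puts chloro in place of hydrogen on an aromatic carbon, and it gave a 1.1-fold lower number from compound 2 to compound 3 (0.04 log units; within the scatter). One small step is thin evidence, so no change beyond the scatter is expected in this assay. The expected step is a 1.2-fold lower number from compound 2 to compound 4 (0.09 log units; within the scatter). The estimate for compound 4 is 25000 nM, with an expected range from 10000 nM to 60000 nM.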

Compound 4, half-maximal inhibitory concentration: 29000 nM
The estimate for compound 4 lay 1.2-fold (0.06 log units) below the measured number; low and high end bracket the measured number.
By their numbers in this assay, from the lowest: compounds 3, 4 and 2 (each within the scatter of the next). At a limit, above all of these: compound 1.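

In this assay, the step for bromo in place of hydrogen, para to a hydroxy group, is a 1.1-fold lower number from compound 2 to compound 4 (0.03 log units; within the scatter). Chloro in compound 3 and bromo in compound 4 therefore both stay within the scatter of compound 2, so neither halogen shifts the number. Compound 1 alone gives a limit rather than a number: the limit of > 100000 nM in this assay, at which 1 of the 4 values shown sits.

Still open, from the compounds shown here alone, is whether a different group at this position, such as an amine or a carboxylic acid, would move the number beyond the scatter.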